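The source may hold more compounds than are shown below. What is called first, only, known or untested is meant among the compounds shown, and "the series" means these compounds.

Compound 1 `Cc1cc(C)c(NC(=O)N(Cc2ccc(N3CCN(C)CC3)cc2)C2CCCCCC2)c(C)c1`: 57 nM
Compound 2 `Cc1cc(C)c(NC(=O)N(Cc2cccc(-c3cc[nH]n3)c2)C2CCCC2)c(C)c1`: 22 nM

In an assay on microsomes from intestine for inhibition of acyl-CoA:cholesterol acyltransferase (Oryctolagus cuniculus) (a higher number here means a weaker inhibitor, a lower number a stronger inhibitor), compound 1 gives the higher of the two numbers shown, while compound 2 gives a lower number, a gap that lies beyond the scatter. Compound 3 `Cc1cc(C)c(NC(=O)N(Cc2ccc(-c3cccnc3)cc2)C2CCCCCC2)c(C)c1` differs from compound 1 in one place: pyridin-3-yl in place of 4-methylpiperazin-1-yl on an aromatic carbon. Within the data shown here, no measured pair shows this change, so nothing here says which way it should go. The step is expected to stay within the scatter of this assay, estimated as a 1.1-fold lower number from compound 1 to compound 3 (0.06 log units; within the scatter). For compound 3 the expected value in this assay is 50 nM, with a range from 15 nM to 200 nM.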

Compound 3, half-maximal inhibitory concentration: 130 nM
Compound 3: the middle estimate sits 2.6-fold (0.41 log units) below what was measured; measured number inside the range.
By their numbers in this assay, from the lowest: compound 2; then compound 1; then compound 3.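

In this assay pyridin-3-yl in place of 4-methylpiperazin-1-yl, on an aromatic carbon para to a large group, gives a 2.3-fold higher number from compound 1 to compound 3 (0.36 log units; beyond the scatter) and so shows that this position is sensitive to the group it carries. The step is modest, and it rests on this single pair. Nothing measured here accounts for the shift. As far as these compounds go, whether a morpholine ring or a simple dimethylamino group at this place would sit nearer compound 1 or compound 3 stays open. Nor can this one pair say whether the step would carry over to the core of compound 2.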